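This account rests on a few compounds, and the source may have more. Where it says the series, first, only, none or still open, it means among the compounds named here.

Compound 1 `O=C1c2c(Cl)c(Cl)c(Cl)c(Cl)c2C(=O)N1Cc1ccccn1` and compound 3 `O=C1c2c(Cl)c(Cl)c(Cl)c(Cl)c2C(=O)N1c1ncccn1` share a core and differ in one place: pyrimidin-2-yl in place of (pyridin-2-yl)methyl on an amide-type nitrogen in a ring. In a functional assay on the whole organism with Rattus norvegicus as the target, read by spectrophotometry, with stated times of 14 days and 3 days, at a dose of 10 mg/kg by the oral route (on this read-out higher numbers stand for more inhibition at the one dose given (going by the name of the read-out) and lower numbers for less inhibition), compound 1 gives 23%, while compound 3 gives 5%, so this change produced a number 18 percentage points lower from compound 1 to compound 3 (beyond the scatter).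

Compound 2 `O=C1c2c(Br)c(Br)c(Br)c(Br)c2C(=O)N1Cc1ccccn1` has a different core; how its core differs from that of compound 1 is not broken down here. In this assay compound 2 gives 35%, the highest of the three numbers measured.

Compound 4 `O=C1c2c(Br)c(Br)c(Br)c(Br)c2C(=O)N1c1ncccn1` is not yet measured. It stands to compound 2 as compound 3 stands to compound 1: pyrimidin-2-yl in place of (pyridin-2-yl)methyl on an amide-type nitrogen in a ring. Because the earlier step was a number 18 percentage points lower from compound 1 to compound 3 (beyond the scatter), a step of similar size is expected here, namely a number 17 percentage points lower from compound 2 to compound 4 (beyond the scatter). Compound 4 is therefore estimated to give 18% in this assay, most likely between 5% and 32%.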

Compound 4, a percentage reported as inhibition, in the whole organism at one dose (the size of the read-out at that dose, not a potency): 28%
For compound 4 the middle estimate is 10 percentage points below the measured one, within the range that was stated.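

In this assay, putting pyrimidin-2-yl in place of (pyridin-2-yl)methyl on the core of compound 2 gives a number 7 percentage points lower from compound 2 to compound 4 (within the scatter). Set beside the same change on the other core, the two steps are no further apart than repeated measurements would allow: the same change on two cores in this assay, a number 18 percentage points lower (beyond the scatter) from compound 1 to compound 3 and a number 7 percentage points lower (within the scatter) from compound 2 to compound 4, 11 percentage points apart, within the scatter of two such steps This gives no sign that the change behaves differently on the two cores, but with only one pair per core it does not prove that the change carries over, and on the core of compound 2 the step cannot be told from scatter.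

The compounds shown carry only these two groups on the ring nitrogen. On these data alone, what an amine, a carboxylic acid or a longer chain would do there remains open.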